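Methyl on the acid side chain of compound 2

This account rests on a few compounds, and the source may have more. Where it says the series, first, only, none or still open, it means among the compounds named here.

- compound 1 `O=C(O)Cn1nc(Cc2nc3cc(Cl)c(OCC(F)F)cc3[nH]2)c2ccccc2c1=O`: 82400 nM
- compound 2 `O=C(O)Cc1nn(Cc2cn3cc(OCC4CC4)c(Cl)cc3n2)c2ccccc2c1=O`: 2010000 nM

In an ADME assay on the whole organism (Mus musculus, strain CD1) for pharmacokinetics, read by LC-MS, with a stated time of 24 h, at a dose of 5 mg/kg by the oral route (on this read-out lower numbers stand for lower exposure and higher numbers for higher exposure at the dose given), compound 2 is the higher of the two measured compounds at 2010000 nM, and its gap to compound 1 lies beyond the scatter. Compound 3 `C[C@H](C(=O)O)c1nn(Cc2cn3cc(OCC4CC4)c(Cl)cc3n2)c2ccccc2c1=O` has methyl in place of hydrogen on a saturated chain carbon bound to an aromatic carbon and a carbonyl carbon. Within the data shown here, no measured pair shows this change, so the expectation has little support. In this assay the estimated change is a 1.3-fold lower number from compound 2 to compound 3 (0.13 log units; within the scatter), a slight fall and no step beyond the scatter. For compound 3 the expected value is 1500000 nM, with an estimated range from 500000 nM to 4000000 nM.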

Compound 3, maximal plasma concentration: 2610000 nM
The estimate for compound 3 lay 1.7-fold (0.24 log units) below the measured number; the measured number falls inside the stated range.
By their numbers in this assay, from the lowest: compound 1; then compounds 2 and 3 (each within the scatter of the next).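

In this assay, methyl in place of hydrogen on a saturated chain carbon bound to an aromatic carbon and a carbonyl carbon gives a 1.3-fold higher number from compound 2 to compound 3 (0.11 log units; within the scatter). Among these compounds, this is the first reading at this position: the carboxymethyl to 1-carboxyethyl exchange keeps the maximal plasma concentration within the scatter of compound 2. No available measurement gives a reason for this result. From the compounds shown here alone, whether an ethyl group or a second methyl on this carbon would keep the same level stays open, and the single read-out leaves the rest of the exposure profile open too.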